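A few compounds are considered here, and "the series" means these few. Any claim that something is new, unique, unknown or untested is made for them only; others in the source may bear on it.

Compound 1 `O=Cc1cc(O)c(O)c(Br)c1Br` carries a formyl group on its core, yet in a functional assay on HCT-116 cells (Homo sapiens) for cytotoxicity, read by MTT assay, with a stated time of 96 h (a higher number here means a weaker inhibitor, a lower number a stronger inhibitor), compound 1 gives "not determined" (no result reported), so its standing rests on no number at all. Compound 3 `COCc1cc(O)c(O)c(Br)c1` likewise gives "not determined" (no result reported) in this assay. Going by the values given here, the only measured number comes from compound 2 `OCc1cc(Br)c(O)c(O)c1Br`, which in this assay gives 21400 nM. Compound 4 `OCc1cc(O)c(O)c(Br)c1Br` is reached from compound 1 by one change: hydroxymethyl in place of formyl on an aromatic carbon. No measured step of this kind exists among these compounds, so the direction of the change cannot be read from the data, and nothing shown suggests a move beyond the usual scatter. Compound 4 is expected to give about 20000 nM in this assay, within a range from 7000 nM to 60000 nM.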

Compound 4, half-maximal inhibitory concentration: 20400 nM
The estimate for compound 4 lay 1.0-fold (0.01 log units) below the measured number, and the stated range covers the measured number.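

In this assay, going by these compounds alone, compound 1 gives "not determined" (no result reported), so no step to compound 4 can be read. The compounds shown leave open what hydroxymethyl in place of formyl does to the result. No other data explain this result.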